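Chemokine receptor antagonist series: from compound 3 to compound 4

A few compounds are considered here, and "the series" means these few. Any claim that something is new, unique, unknown or untested is made for them only; others in the source may bear on it.

Three measured compounds share one core and differ only in the aryl group on a saturated chain carbon bound to an amine nitrogen in a ring. In a functional assay for antagonist activity at C-X-C chemokine receptor type 3 (Homo sapiens) (a lower number here means a stronger inhibitor, a higher number a weaker inhibitor), compound 1 `CNC(=O)c1cnc(N2CCN(C3CCN(Cc4ccco4)CC3)[C@@H](C)C2)c(Cl)c1` gives 8100 nM. Compound 2 `CNC(=O)c1cnc(N2CCN(C3CCN(Cc4cccs4)CC3)[C@@H](C)C2)c(Cl)c1` gives 1980 nM. Compound 3 `CNC(=O)c1cnc(N2CCN(C3CCN(Cc4ccc(C)cc4)CC3)[C@@H](C)C2)c(Cl)c1` gives 87 nM, the lowest of the three numbers; the steps of a 93-fold lower number from compound 1 to compound 3 (1.97 log units; beyond the scatter) and a 23-fold lower number from compound 2 to compound 3 (1.36 log units; beyond the scatter) both run beyond the scatter, as does a 4.1-fold lower number from compound 1 to compound 2 (0.61 log units; beyond the scatter).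

Compound 4 `CNC(=O)c1cnc(N2CCN(C3CCN(Cc4ccc(Cl)cc4F)CC3)[C@@H](C)C2)c(Cl)c1` is not yet measured. The change is 4-chloro-2-fluorophenyl in place of 4-methylphenyl on a saturated chain carbon bound to an amine nitrogen in a ring. Going by the values given here, the steps that bear on it are a 93-fold lower number from compound 1 to compound 3 (1.97 log units; beyond the scatter) and a 23-fold lower number from compound 2 to compound 3 (1.36 log units; beyond the scatter): both exchange the group at this same position and both were large, favouring the six-membered carbon ring. Among the compounds with values here, no measured step exchanges one substituted phenyl for another, so the size of the present step is not anchored by the data. Compound 4 keeps the six-membered carbon ring, so no step beyond the scatter is expected in this assay in either direction. On this basis compound 4 is estimated at 100 nM, with a range from 30 nM to 400 nM. The implied step, a 1.1-fold higher number from compound 3 to compound 4 (0.06 log units; within the scatter), is expected to stay within the usual scatter.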

Compound 4, half-maximal inhibitory concentration: 18 nM
Compound 4: middle estimate off by 5.6-fold (0.74 log units), on the high side; the whole stated range lies above it.
By their numbers in this assay, from the lowest: compound 4; then compound 3; then compound 2; then compound 1.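

In this assay, the position separates substituted phenyl groups from one another as well as from furan-2-yl and thiophen-2-yl: 4-chloro-2-fluorophenyl in place of 4-methylphenyl gives a 4.8-fold lower number from compound 3 to compound 4 (0.68 log units; beyond the scatter). The same group widens the spread across this position, with a 110-fold lower number from compound 2 to compound 4 (2.04 log units; beyond the scatter) and a 450-fold lower number from compound 1 to compound 4 (2.65 log units; beyond the scatter), which makes compound 4 the strongest inhibitor of the four. No measurement here bears on what lies behind the step from 4-methylphenyl to 4-chloro-2-fluorophenyl.

The entering group differs from 4-methylphenyl by both a chlorine and a fluorine, so the compounds shown do not divide the step between the two halogens, and 4-chlorophenyl and 2-fluorophenyl on the same saturated chain carbon would be the direct comparisons. As far as these compounds go, it also remains open whether a ring bearing a different substituent, such as 4-methoxyphenyl or 4-cyanophenyl, would give a lower or higher number than compound 4, and whether the step holds on any core other than the shared one.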